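The source may report more compounds than this note shows. Statements on the series, on what has been measured and on what is new or still open speak of the compounds shown alone.

In an in vitro assay on 293-EBNA cells for binding affinity to corticotropin-releasing factor receptor 1 (Homo sapiens) (a lower number here means a stronger inhibitor, a higher number a weaker inhibitor), compound 1 `CCC(CC)Nc1nc(C)nc2c1nnn2-c1c(C)cc(C)cc1C` gives 5.7 nM, and compound 2 `COCC(COC)Nc1nc(C)nc2c1nnn2-c1ccc(C(C)C)cc1Br` gives 10.3 nM; the two values lie within the scatter of each other, so no order between them is claimed. Compound 3 `CCC(Nc1nc(C)nc2c1nnn2-c1ccc(C(C)C)cc1Br)C(=O)OC` differs from compound 2 by 1-(methoxycarbonyl)propyl in place of 2-methoxy-1-(methoxymethyl)ethyl on a nitrogen on an aromatic ring. Within the data shown here, no measured pair shows an exchange of this kind, so the step in this assay is expected to be small, a modest move toward a higher number, with no change beyond the scatter about equally possible. Compound 3 is accordingly expected to give 15 nM in this assay, with a likely range of 5 nM to 45 nM, which corresponds to an expected step of a 1.5-fold higher number from compound 2 to compound 3 (0.16 log units; within the scatter).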

Compound 3, inhibition constant: 19.4 nM
Compound 3: the middle estimate sits 1.3-fold (0.11 log units) below what was measured, and the stated range covers the measured number.
By their numbers in this assay, from the lowest: compounds 1, 2 and 3 (each within the scatter of the next, the first and the last beyond it).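

In this assay, 1-(methoxycarbonyl)propyl in place of 2-methoxy-1-(methoxymethyl)ethyl on a nitrogen on an aromatic ring gives a 1.9-fold higher number from compound 2 to compound 3 (0.27 log units; within the scatter), so on this core the exchange stays within the scatter. The two groups match in heavy atoms, hydrogen-bond donors and acceptors, and differ in the double bond outside aromatic rings that 1-(methoxycarbonyl)propyl carries. Nothing at hand explains this result. Still open, from the compounds shown here alone, is whether a carboxylic acid or an amine at this place, or a longer chain, would also stay within the scatter of compound 2.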